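Swapping an Amino Linker for an Ether on a Potent Scaffold

The compounds below may be only part of what the source reports. "The series", "measured", "known", "first", "only" and "open" are said of these compounds alone.

Compound 2 `Cc1cc(Cl)cc(-c2ccnc3cc(CN4C(=O)C5C(C4=O)C5(C)C)sc23)c1NC1CCCNC1` belongs to a small group of inhibitors of a deubiquitinating enzyme, examined in an assay on isolated protein for inhibition of ubiquitin carboxyl-terminal hydrolase 7 (Homo sapiens), read by fluorescence, with stated times of 30 min and 1 h; on this read-out lower numbers stand for stronger inhibition and higher numbers for weaker inhibition. In this assay compound 2 gives 0.78 nM. Two relatives share the same core but carry a different group at the same place on it: compound 1 `Cc1cc(Cl)cc(-c2ccnc3cc(CN4C(=O)C5CC5C4=O)sc23)c1C[C@H]1OCCN[C@@H]1C` gives 1.5 nM in this assay, and compound 3 `Cc1cc(Cl)cc(-c2ccnc3cc(CN4C(=O)CCC4=O)sc23)c1CN1[C@@H](C)CNC[C@@H]1C` gives 0.32 nM. Among these three numbers compound 2 sits second highest. Its value and that of compound 1 lie within the usual scatter of the measurement, so no order between the two can be claimed, whereas the gap to compound 3 lies beyond that scatter.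

Compound 4 `Cc1cc(Cl)cc(-c2ccnc3cc(CN4C(=O)C5C(C4=O)C5(C)C)sc23)c1O[C@@H]1CCNC[C@@H]1C` has not yet been measured. It differs from compound 2 in one place: (3-methylpiperidin-4-yl)oxy in place of (piperidin-3-yl)amino on an aromatic carbon. Within the data shown here, no pair of measured compounds isolates such an exchange, so the judgement rests on the three values alone, which all fall close together despite quite different groups at the same place. Compound 4 is therefore expected to remain in the same region, with an estimated step of a 1.9-fold higher number from compound 2 to compound 4 (0.28 log units; within the scatter), not beyond the scatter. The value of compound 4 in this assay is estimated at 1.5 nM, with a likely range from 0.4 nM to 6 nM.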

Compound 4, half-maximal inhibitory concentration: 0.18 nM
The estimate for compound 4 lay 8.3-fold (0.92 log units) above the measured number; the measured number lies below the stated range.
By their numbers in this assay, from the lowest: compounds 4 and 3 (each within the scatter of the next); then compounds 2 and 1 (each within the scatter of the next).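

In this assay, placing (3-methylpiperidin-4-yl)oxy in place of (piperidin-3-yl)amino gives a 4.3-fold lower number from compound 2 to compound 4 (0.64 log units; beyond the scatter), so the group on this aromatic carbon, ortho to a methyl group and para to a chloro group, does affect the read-out. The earlier compounds shown here could not show this, as they also differ in the group on the other side of the shared core, and no single exchange could be read from them. This step holds that other side fixed and shows that the group at this position can be replaced, with the linking amino nitrogen giving way to an oxygen, without any loss of inhibition. No measurement here bears on why the number falls.

The exchange alters the linking atom, the point of attachment on the ring and the added methyl together, so the compounds shown leave open which of these changes carries the step. On these data alone, an unmethylated (piperidin-4-yl)oxy group and a (piperidin-3-yl)oxy group on the same core would separate these changes, and the mirror-image arrangement of the two stereocentres also remains open.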